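The source may hold more compounds than are shown below. What is called first, only, known or untested is meant among the compounds shown, and "the series" means these compounds.

Compound 1 `CCn1c(C(=O)NCCCN(C)C)ccc1C(CC)(CC)c1ccc(OCC(O)C(C)(C)C)c(C)c1` carries a (3-(dimethylamino)propyl)amino group on its carbonyl carbon, and in a functional assay on MCF7 cells (Homo sapiens), read by MTT assay, with a stated time of 48 h (on this read-out lower numbers stand for stronger inhibition and higher numbers for weaker inhibition), compound 1 gives 490 nM. Compound 2 `CCn1c(C(=O)N(C)CCC#N)ccc1C(CC)(CC)c1ccc(OCC(O)C(C)(C)C)c(C)c1` differs from it only in having (2-cyanoethyl)(methyl)amino in place of that group. In this assay compound 2 gives > 50000 nM, which is a limit of the assay rather than a number. The step of an at least 100-fold higher number from compound 1 to compound 2 (2.00 log units; beyond the scatter) is therefore known only as a lower bound, and compound 2 stands at the limit of > 50000 nM in this assay, at which 1 of the 2 values shown sits, among the two values at hand.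

Compound 3 `CCn1c(C(=O)N(CCC#N)CCC#N)ccc1C(CC)(CC)c1ccc(OCC(O)C(C)(C)C)c(C)c1` is the next compound in this line. Relative to compound 2 the change is cyanomethyl in place of hydrogen on a saturated chain carbon bound to an amide-type nitrogen; cut one bond further out it reads methyl to 2-cyanoethyl, so the amide nitrogen of compound 3 carries two 2-cyanoethyl chains and no basic amine. Among the measured compounds shown here, the only step that bears on this is an at least 100-fold higher number from compound 1 to compound 2 (2.00 log units; beyond the scatter), which shows that moving from the basic amine of compound 1 to the nitrile-bearing amide of compound 2 cost at least that much. Nothing in the two values suggests that adding a second nitrile restores what was lost, so compound 3 is expected to remain at the limit in this assay, with an estimated step that the limit leaves unreadable from compound 2 to compound 3. Compound 3 is estimated at 70000 nM, in a range from 20000 nM to 250000 nM.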

Compound 3, half-maximal inhibitory concentration: 480 nM
Compound 3: middle estimate off by 150-fold (2.16 log units), on the high side, and the stated range ends above it.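

Compound 3 shows that this position on the amide nitrogen is far more sensitive than compound 2 alone suggested: in this assay, cyanomethyl in place of hydrogen on a saturated chain carbon bound to an amide-type nitrogen, which reads as methyl to 2-cyanoethyl when cut one bond further out, gives an at least 100-fold lower number from compound 2 to compound 3 (2.01 log units; beyond the scatter). That step has only one measured end, as compound 2 stands at a limit of the assay and not at a number: the limit of > 50000 nM in this assay, at which 1 of the 3 values shown sits. The comparison with compound 1 adds that the (3-(dimethylamino)propyl)amino group is not needed for this level of activity in the series, since replacing it with the two 2-cyanoethyl chains gives a 1.0-fold lower number from compound 1 to compound 3 (0.01 log units; within the scatter).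

The compounds shown leave open whether the nitrile itself matters or whether a second chain of this length on the amide nitrogen is enough, a question that two plain propyl chains, or two chains ending in a hydroxyl group, would address. They also leave open whether a single 2-cyanoethyl chain paired with an ethyl group or a longer chain would behave like compound 2 or like compound 3.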